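Removing the Amino Group from a Diyne-Linked Quinoline Core

The source may hold more compounds than are shown below. What is called first, only, known or untested is meant among the compounds shown, and "the series" means these compounds.

Of the compounds shown here, three have been tested. Compound 1 `Nc1ccnc2cc(C#Cc3c(F)cccc3F)ccc12` gives 97.7% in a functional assay on LS174T cells (Homo sapiens) for inhibition, with a stated time of 4 days, tested at 10 uM; on this read-out lower numbers stand for a weaker effect and higher numbers for a stronger effect at the one concentration tested. Compound 2 `Fc1cccc(F)c1C#Cc1cnc2ccccc2c1` gives 90.4%, and compound 3 `Nc1ccc2ncc(C#Cc3c(F)cccc3F)cc2c1` gives 9.2%. Compounds 1 and 3 share the same atoms joined differently; the difference between the two cores is not broken down here. Compound 2 is compound 3 without its amino group, the change being (hydrogen in place of amino on an aromatic carbon), and the step of a number 81.2 percentage points higher from compound 3 to compound 2 (beyond the scatter) was measured.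

Compound 4 `Fc1cccc(F)c1C#Cc1ccc2cccnc2c1` is still to be measured. It arises from compound 1 by the same kind of change, (hydrogen in place of amino on an aromatic carbon), though the place differs: here the ring holds one nitrogen and the carbon is ortho to a fused ring, meta to a fused ring and opposite the ring nitrogen, whereas in compound 3 the ring is of carbon only and the carbon is meta and para to fused rings. Because compound 1 already gives 97.7% and compound 2 gives 90.4%, the step of a number 12.7 percentage points lower from compound 1 to compound 4 (beyond the scatter) is expected to be small. Compound 4 is estimated at 85%, between 55% and 98%.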

Compound 4, a percentage reported as inhibition, at one concentration (the size of the read-out at that concentration, not a potency): 99.4%
The estimate for compound 4 lay 14.4 percentage points below the measured number, and the stated range ends below it.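

In this assay, putting hydrogen in place of amino on the core of compound 1 gives a number 1.7 percentage points higher from compound 1 to compound 4 (within the scatter), so on this core the read-out does not register the loss of the amino group. The change therefore does not carry over with the same result from one core to the other: the same change on two cores in this assay, a number 81.2 percentage points higher (beyond the scatter) from compound 3 to compound 2 and a number 1.7 percentage points higher (within the scatter) from compound 1 to compound 4, 79.5 percentage points apart, beyond the scatter of two such steps These two pairs show that the outcome of this change depended on the core in this series, but they do not explain why, and two cores are too few to predict the outcome on a third; a read-out at one concentration also says nothing about potency.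

The compounds shown leave open whether a methoxy or a dimethylamino group in place of the amino group would track hydrogen or amino on either core. They also leave open whether the contrast between the two cores would persist if the two fluorines were replaced by chlorines.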